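This account rests on a few compounds, and the source may have more. Where it says the series, first, only, none or still open, it means among the compounds named here.

In a functional assay on cells (Neutrophil, Homo sapiens) for inhibition, with a stated time of 10 min (on this read-out higher numbers stand for weaker inhibition and lower numbers for stronger inhibition), compound 1 (`O=C(Nc1cccc2ccccc12)N1c2ccnn2CC1c1ccccc1`) reads > 1000 nM as a limit of the assay and not a number. Compound 2 (`CCOC(=O)c1cnn2c1N(C(=O)Nc1ccccc1)C(c1ccccc1)C2`) reads > 1000 nM as a limit too. Among the measured compounds shown here, compound 3 (`CCOC(=O)c1cnn2c1N(C(=O)Nc1ccccc1F)C(c1ccccc1)C2`) gives 7.5 nM as the only actual number of the three. For the measured compounds named here, the one measured step is large, an at least 130-fold lower number from compound 2 to compound 3 (2.12 log units; beyond the scatter) in this case, and it falls on the aromatic ring that changes next. Compound 4 (`CCOC(=O)c1cnn2c1N(C(=O)Nc1cccc3ccccc13)C(c1ccccc1)C2`) differs from compound 3 by naphthalen-1-yl in place of 2-fluorophenyl on an amide-type nitrogen and so has naphthalen-1-yl in place of 2-fluorophenyl on an amide-type nitrogen. Compound 4 therefore has no fluoro, the change behind that step. Compound 1 also carries naphthalen-1-yl on an amide-type nitrogen, and its reading of > 1000 nM is a limit. A sizeable step toward a higher number, meaning weaker inhibition, is therefore expected in this assay but with wide uncertainty. The expected change is a 13-fold higher number from compound 3 to compound 4 (1.12 log units; beyond the scatter) on this estimate. For compound 4 the estimated value is 100 nM with an expected range from 5 nM to 2000 nM in this assay when a number is obtained.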

Compound 4, half-maximal inhibitory concentration: 206 nM
Beside the measured number, compound 4's estimate is 2.1-fold (0.31 log units) below it, and the stated range covers the measured number.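

In this assay, naphthalen-1-yl on the amide-type nitrogen gives a measurable number where phenyl there does not, with an at least 4.8-fold lower number from compound 2 to compound 4 (0.68 log units; beyond the scatter). At that same nitrogen it still falls well short of 2-fluorophenyl, with a 27-fold higher number from compound 3 to compound 4 (1.44 log units; beyond the scatter), so a gain over phenyl does not require the fluoro, though the fluoro gives by far the larger one. With naphthalen-1-yl held fixed, the other part of the molecule also counts: having ethoxycarbonyl on the core goes with an at least 4.8-fold lower number from compound 1 to compound 4 (0.68 log units; beyond the scatter).

On these data alone, the true size of the two steps that start from a limit stays open because they can only be read as bounds: the limit of > 1000 nM in this assay, at which 2 of the 4 values shown sit. Also open is how chloro or methoxy in place of the fluoro, or a carboxylic acid or an amide in place of ethoxycarbonyl, would read.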